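A few compounds are considered here, and "the series" means these few. Any claim that something is new, unique, unknown or untested is made for them only; others in the source may bear on it.

Of the compounds shown here, two have been read so far in an ADME assay on RAW264.7 cells (Mus musculus) for cytotoxicity, read by MTT assay, with a stated time of 24 h (a lower number here means that less compound is tolerated, a higher number that more compound is tolerated), as working data. Compound 1 (`Cc1ccc(C2=NN(C3=NC(=O)CS3)C(c3ccccc3C)C2)cc1C`) gives 317000 nM and compound 2 (`Cc1ccccc1C1CC(c2ccc(Cl)c(Cl)c2)=NN1C1=NC(=O)CS1`) gives 179000 nM and so stands within the scatter of compound 1. Compound 3 (`Cc1ccc(C2CC(c3ccc(Cl)c(Cl)c3)=NN2C2=NC(=O)CS2)cc1`) keeps the 3,4-dichlorophenyl group of compound 2 and carries 4-methylphenyl in place of 2-methylphenyl on a saturated ring carbon. Among the measured compounds shown here, the only measured step is a 1.8-fold lower number from compound 1 to compound 2 (0.25 log units; within the scatter) and it lies within the scatter. That step changes a different place, the group on a carbon with a double bond to nitrogen. For the measured compounds named here, no measured compound shows what a change on the saturated ring carbon does, so the series offers no direct guide to this swap. With so little to go on, the expected outcome is a 1.1-fold higher number from compound 2 to compound 3 (0.05 log units; within the scatter) and nothing beyond the scatter in either direction. Compound 3 is estimated at 200000 nM in this assay with 90000 nM to 450000 nM as the expected range.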

Compound 3, half-maximal cytotoxic concentration: 279000 nM
Estimate against measurement, compound 3: 1.4-fold (0.14 log units) below, within the range that was stated.
By their numbers in this assay, from the lowest: compounds 2, 3 and 1 (each within the scatter of the next).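

Among the compounds shown here, the step at the saturated ring carbon in this assay is a 1.6-fold higher number from compound 2 to compound 3 (0.19 log units; within the scatter) and gives the first reading at this place, where 4-methylphenyl takes the place of 2-methylphenyl with the atom count and the hydrogen-bond counts unchanged. For the compounds shown here, until now, the only step available was a 1.8-fold lower number from compound 1 to compound 2 (0.25 log units; within the scatter) and it concerned the group on a carbon with a double bond to nitrogen, so the series now holds one step at each of two places, and neither lies beyond the scatter. Nothing on hand bears on why the 2-methylphenyl and 4-methylphenyl compounds read as they do in this cytotoxicity read-out.

Open, as far as these compounds go, is whether a group of another kind on the phenyl ring at the saturated ring carbon, such as an amine or a carboxylic acid, or a longer chain in place of the methyl, would give a step beyond the scatter in this assay or stay within it. Also open, from the compounds shown here alone, is whether 3-methylphenyl at this carbon, or a change on the group of 6 heavy atoms on the ring nitrogen, would separate any compound from compound 2 by more than the scatter.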